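Benzylamine series: dichloropyridinyl in place of fluorophenyl

The source may hold more compounds than are shown below. What is called first, only, known or untested is meant among the compounds shown, and "the series" means these compounds.

Of the compounds shown here, two have numbers so far. Compound 1 `COc1cc(CNCc2ccncc2)ccc1OCc1cccc(F)c1` gives 4800 nM in a functional assay on HeLa cells (Homo sapiens) for inhibition, with a stated time of 72 h; a higher number here means that more compound is needed for the effect, a lower number that less compound is needed. Compound 2 `COc1cc(CNCc2ccncc2)ccc1OCc1ccc(F)cc1` gives 6400 nM in this assay. Going by the values given here, the only step between them, a 1.3-fold higher number from compound 1 to compound 2 (0.12 log units; within the scatter), is within the scatter, so compound 2 and compound 1 cannot be told apart on these two numbers, and compound 2 has no distinct standing of its own.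

Compound 3 `COc1cc(CNCc2ccncc2)ccc1OCc1cnc(Cl)c(Cl)c1` is not yet measured. It differs from compound 2 as follows: 5,6-dichloropyridin-3-yl in place of 4-fluorophenyl on a saturated chain carbon bound to an oxygen on an aromatic ring. Among the compounds with values here, the one measured step, from compound 1 to compound 2, exchanges only the position of a fluorine on the same ring and stayed within the scatter; the change to compound 3 replaces the ring itself, which no measured step covers. There is thus no basis to expect a step in either direction beyond the scatter, and the uncertainty is wider than for the measured pair.

For compound 3 the expected number in this assay is 6000 nM, with a range from 2000 nM to 18000 nM. This estimate corresponds to a step of a 1.1-fold lower number from compound 2 to compound 3 (0.03 log units; within the scatter), expected to lie within the scatter.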

Compound 3, half-maximal effective concentration: 220 nM
Compound 3: the middle estimate sits 27-fold (1.44 log units) above what was measured; measured number outside the range, below it.
By their numbers in this assay, from the lowest: compound 3; then compounds 1 and 2 (each within the scatter of the next).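

In this assay, going by these compounds alone, this position responds strongly to the ring it carries: 5,6-dichloropyridin-3-yl in place of 4-fluorophenyl gives the largest step so far (a 29-fold lower number from compound 2 to compound 3 (1.46 log units; beyond the scatter)), and the same ring in place of 3-fluorophenyl gives a step of similar order (a 22-fold lower number from compound 1 to compound 3 (1.34 log units; beyond the scatter)). Within the data shown here, the only earlier step moved a fluorine on an unchanged ring and stayed within the scatter (a 1.3-fold higher number from compound 1 to compound 2 (0.12 log units; within the scatter)), so it gave no sign that the group on the saturated chain carbon bound to an oxygen on an aromatic ring could shift the number this far, and compound 3 now needs less compound for the effect than both compound 1 and compound 2. Nothing available explains this gain or ties it to any one part of the new ring.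

The change brings in a ring nitrogen and two chlorines at once, so the compounds shown do not separate their shares; 3,4-dichlorophenyl and 6-chloropyridin-3-yl would be the closest comparisons at this position. Also open, going by these compounds, is whether the gain survives a longer chain between the oxygen and the 5,6-dichloropyridin-3-yl ring.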